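This account rests on a few compounds, and the source may have more. Where it says the series, first, only, none or still open, it means among the compounds named here.

Working notes on the series. In an ADME assay on CHO cells (Cricetulus griseus) for cytotoxicity, read by LDH release (a higher number here means a weaker inhibitor, a lower number a stronger inhibitor), compound 1 `CC(Oc1ccc(Cl)cc1Cl)C(=O)N(C)Cc1ccc(F)cc1` stands as "not determined" (no result reported) and supplies no number. In this assay, among the measured compounds shown here, compound 2 `CC(Oc1ccc(Cl)cc1Cl)C(=O)NCc1cccc(F)c1` gives 27000 nM and compound 3 `CC(Oc1ccc(Cl)cc1Cl)C(=O)NCc1cccc(Cl)c1` gives 19000 nM, so these two values sit within the scatter of each other and are the only numbers available.

Compound 4 `Cc1ccccc1CNC(=O)C(C)Oc1ccc(Cl)cc1Cl` has not been measured. Its difference from compound 3 is 2-methylphenyl in place of 3-chlorophenyl on a saturated chain carbon bound to an amide-type nitrogen.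

For the measured compounds named here, one measured step bears on this, and only loosely: a 1.4-fold lower number from compound 2 to compound 3 (0.15 log units; within the scatter), with chloro in place of fluoro on an aromatic carbon, stays within the scatter. Going by the values given here, no measured compound carries the 2-methylphenyl group, so the evidence is thin and the range is kept wide. No shift beyond the scatter is expected, and the expected step is a 1.2-fold higher number from compound 3 to compound 4 (0.06 log units; within the scatter), with no firm direction. Compound 4 is estimated at 22000 nM, with an expected range of 9000 nM to 55000 nM in this assay.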

Compound 4, half-maximal inhibitory concentration: > 100000 nM
Compound 4: a limit, no number; the forecaster's own chance of this, stated with the estimate: 15%; middle value at least 4.5-fold (0.65 log units) away from the limit.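

In this assay compound 4 stands at a limit of the assay and not at a number: the limit of > 100000 nM in this assay, at which 1 of the 4 values shown sits. Replacing the whole aryl group on the saturated chain carbon bound to an amide-type nitrogen moves the read-out beyond the scatter, with an at least 5.2-fold higher number from compound 3 to compound 4 (0.72 log units; beyond the scatter) and an at least 3.7-fold higher number from compound 2 to compound 4 (0.56 log units; beyond the scatter), whereas the exchange of chloro for fluoro stayed within it, at a 1.4-fold lower number from compound 2 to compound 3 (0.15 log units; within the scatter). This place therefore responds to the choice of group, and in the direction of a weaker inhibitor, which compounds 2 and 3 alone did not show.

As far as these compounds go, the true size of both new steps stays open, as does whether the shift goes with the methyl group or with the loss of the halogen. From the compounds shown here alone, how a plain phenyl or a ring bearing a carboxylic acid would read at this place also stays open.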